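Compound 3 to compound 4: one aromatic group exchanged

The source may hold more compounds than are shown below. What is called first, only, known or untested is meant among the compounds shown, and "the series" means these compounds.

Compound 1 `CC(C)N(Cc1cccc(OCCCCCC(=O)O)c1)C(=O)c1ccc(-c2cccc3ccccc23)cc1`: < 1.3 nM (a limit)
Compound 2 `CC(C)N(Cc1cccc(OCCCCCC(=O)O)c1)C(=O)c1ccc(-c2ccncc2)cc1`: > 26000 nM (a limit)
Compound 3 `CC(C)N(Cc1cccc(OCCCCCC(=O)O)c1)C(=O)c1ccc(-c2ccc3cc[nH]c3c2)cc1`: > 26000 nM (a limit)

In an ADME assay on BJ cells (Homo sapiens) for cytotoxicity, read by CellTiter-Glo and resazurin assay, with a stated time of 72 h (a higher number here means that more compound is needed for the effect, a lower number that less compound is needed), compound 3 gives > 26000 nM, which is a limit and not a number. It therefore sits at the limit of > 26000 nM in this assay, at which 2 of the 3 values shown sit. Compound 4 `CC(C)N(Cc1cccc(OCCCCCC(=O)O)c1)C(=O)c1ccc(-c2cccc(C(F)(F)F)c2)cc1` differs from it at one place: 3-(trifluoromethyl)phenyl in place of 1H-indol-6-yl on an aromatic carbon. Two measured steps changed this same place, an at least 20000-fold higher number from compound 1 to compound 2 (4.30 log units; beyond the scatter) and an at least 20000-fold higher number from compound 1 to compound 3 (4.30 log units; beyond the scatter), both large and beyond the scatter. A third, a step that the two limits leave unreadable from compound 2 to compound 3, tells nothing. Neither large step involves the entering 3-(trifluoromethyl)phenyl, so the size is uncertain. Because of an at least 20000-fold higher number from compound 1 to compound 3 (4.30 log units; beyond the scatter) some movement to a lower number is expected, of moderate size. The expected change is an at least 5.2-fold lower number from compound 3 to compound 4 (0.71 log units; beyond the scatter). For compound 4 the estimate is 5000 nM, with an expected range from 50 nM to 26000 nM.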

Compound 4, half-maximal effective concentration: > 26000 nM
Compound 4: no number, only a limit (the forecaster's own chance of this, stated with the estimate: 50%); middle value at least 5.2-fold (0.71 log units) from the limit.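

In this assay, 3-(trifluoromethyl)phenyl in place of naphthalen-1-yl gives a third large step at this position: an at least 20000-fold higher number from compound 1 to compound 4 (4.30 log units; beyond the scatter). This entering group holds no nitrogen, unlike pyridin-4-yl and 1H-indol-6-yl, so a step of this kind does not depend on nitrogen in the new group. Compound 4 gives only a limit, and its steps to compound 2 and compound 3 cannot be read: the limit of > 26000 nM in this assay, at which 3 of the 4 values shown sit.

The compounds shown leave open how far the true values of compounds 2, 3 and 4 differ. They also leave open whether an unsubstituted phenyl or a naphthalen-2-yl at this position would sit at either limit.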